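Removing the Nitro Group from a Macrocyclic Amide

The source may report more compounds than this note shows. Statements on the series, on what has been measured and on what is new or still open speak of the compounds shown alone.

Compound 1 `O=C1NCc2ccc(cc2)-c2cccc(c2)-c2ccc(cc2)CNC(=O)c2cccc(c2)OCc2cc(cc([N+](=O)[O-])c2)COc2cccc1c2` is one of three macrocycles tested in a functional assay on cell membranes from cells (Erythrocyte, Homo sapiens), read by spectrophotometry, with a stated time of 30 min, tested at 10 ug/mL; a higher number here means a stronger effect of the compound at the concentration tested, a lower number a weaker effect. In this assay compound 1 gives 66.7%. Compound 3 `O=C1NCc2ccc(cc2)-c2cccc(c2)-c2ccc(cc2)CNC(=O)c2cccc(c2)OCc2cccc(n2)COc2cccc1c2`, a related macrocycle, gives 70.2%, which lies within the usual scatter of the number for compound 1, so the two cannot be told apart. Compound 2 `O=C1COc2ccc3ccccc3c2-c2c(ccc3ccccc23)OCC(=O)NCc2ccc(cc2)-c2cccc(c2)-c2ccc(cc2)CN1` gives 77.3%, and here the gap to compound 1 is beyond the scatter, so compound 1 sits below compound 2 in this assay. No two of these three compounds differ in only one place, so none of them by itself shows how a single change moves the read-out.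

Compound 4 `O=C1NCc2ccc(cc2)-c2cccc(c2)-c2ccc(cc2)CNC(=O)c2cccc(c2)OCc2cccc(c2)COc2cccc1c2` differs from compound 1 in one place: hydrogen in place of nitro on an aromatic carbon. Nothing measured in this set shows what that change does to the read-out. With the rest of the shared core left as it is in compound 1, the step expected from compound 1 to compound 4 is a number 1.3 percentage points higher from compound 1 to compound 4 (within the scatter), in no particular direction and not beyond the scatter. Compound 4 is therefore expected to give about 68% in this assay, with a range from 55% to 80%.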

Compound 4, a percentage reported as activity, at one concentration (the size of the read-out at that concentration, not a potency): 64.3%
Estimate against measurement, compound 4: 3.7 percentage points above; the range from low to high includes it.
By their numbers in this assay, from the lowest: compounds 4, 1, 3 and 2 (each within the scatter of the next, the first and the last beyond it).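

Within the data shown here, this is the first comparison in the set between two compounds that differ in one place. In this assay, hydrogen in place of nitro on this aromatic carbon gives a number 2.4 percentage points lower from compound 1 to compound 4 (within the scatter) and so does not separate the two compounds, which shows that the read-out at the concentration tested stays within the scatter when the nitro group, with its three heavy atoms and two hydrogen-bond acceptors, is absent from this position. No measurement shown here offers a reason for this outcome.

Going by these compounds, only nitro and hydrogen are compared on this carbon, so it remains open whether another group there, such as an amine, a carboxylic acid or a methoxy group, would move the number beyond the scatter. On these data alone, it also remains open whether the same exchange would leave the read-out as little changed on a core other than that of compound 1, and whether this holds at concentrations other than the one tested.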